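The source may report more compounds than this note shows. Statements on the series, on what has been measured and on what is new or still open speak of the compounds shown alone.

Compound 1 `COc1cc(-n2c(-c3ccc(Br)cc3)csc2=S)cc(OC)c1OC`: in a functional assay on T47D cells (Homo sapiens) for cytotoxicity, read by MTT assay, with a stated time of 48 h (a higher number here means a weaker inhibitor, a lower number a stronger inhibitor), compound 1 gives > 100 ug/mL, which is a limit of the assay.
Compound 2 `COc1cc(-n2c(-c3ccc(Cl)cc3)csc2=S)cc(OC)c1OC`: in this assay compound 2 gives > 100 ug/mL, also a limit.
Compound 3 `COc1cc(-n2c(-c3ccc(O)cc3)csc2=S)cc(OC)c1OC`: in this assay compound 3 gives 26.4 ug/mL.

For the measured compounds named here, compound 3 therefore holds the only true number among the three; the other two sit at the limit of > 100 ug/mL in this assay, at which 2 of the 3 values shown sit. Compound 4 `COc1ccc(-c2csc(=S)n2-c2cc(OC)c(OC)c(OC)c2)cc1` differs from compound 3 by methyl in place of hydrogen on an oxygen on an aromatic ring. The steps measured so far bear on it only indirectly: an at least 3.7-fold lower number from compound 1 to compound 3 (0.57 log units; beyond the scatter) and an at least 3.7-fold lower number from compound 2 to compound 3 (0.57 log units; beyond the scatter) show that the hydroxy compound gave the lower number, while a step that the two limits leave unreadable from compound 1 to compound 2. Going by the values given here, no measured step covers hydroxy to methoxy itself, so the move away from hydroxy is expected to give a higher number, of modest size. For compound 4 the estimate is 50 ug/mL, with a range from 18 ug/mL to 140 ug/mL. That corresponds to an expected 1.9-fold higher number from compound 3 to compound 4 (0.28 log units; within the scatter).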

Compound 4, half-maximal inhibitory concentration: > 100 ug/mL
Compound 4: no number, only a limit; the forecaster's own chance of this, stated with the estimate: 35%; middle value at least 2.0-fold (0.30 log units) from the limit.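

Methyl in place of hydrogen on the oxygen gives an at least 3.7-fold higher number from compound 3 to compound 4 (0.57 log units; beyond the scatter) and removes the only true number in this assay. So a change at the hydroxy hydrogen alone, with the oxygen kept, is enough to lose that number, which the bromo and chloro compounds could not show. Compound 3 now stands alone, with the others at one limit: the limit of > 100 ug/mL in this assay, at which 3 of the 4 values shown sit.

The steps from compound 1 and compound 2 to compound 4 cannot be read, since both ends are limits. As far as these compounds go, whether an amine or a longer chain on that oxygen would restore a measurable number stays open.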